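Shortening the Amide Side Chain: Phenethyl to Phenyl

The source may hold more compounds than are shown below. What is called first, only, known or untested is meant among the compounds shown, and "the series" means these compounds.

Of the compounds shown here, three sharing one core have been measured in a functional assay on MDA-MB-231 cells (Homo sapiens) for inhibition, read by MTT assay, with a stated time of 48 h; a lower number here means a stronger inhibitor, a higher number a weaker inhibitor. Compound 1 `COc1cc2cc(C(=O)NCc3ccc(F)cc3)c(=O)oc2cc1OCCCOc1no[n+]([O-])c1S(=O)(=O)c1ccccc1` gives 770 nM, compound 2 `COc1cc2cc(C(=O)NCCCc3ccccc3)c(=O)oc2cc1OCCCOc1no[n+]([O-])c1S(=O)(=O)c1ccccc1` gives 760 nM, and compound 3 `COc1ccc(NC(=O)c2cc3cc(OC)c(OCCCOc4no[n+]([O-])c4S(=O)(=O)c4ccccc4)cc3oc2=O)cc1` gives 730 nM. Compound 2 stands second highest of the three numbers, although its steps of a 1.0-fold lower number from compound 1 to compound 2 (0.01 log units; within the scatter) and a 1.0-fold lower number from compound 2 to compound 3 (0.02 log units; within the scatter) are both within the scatter, as is a 1.1-fold lower number from compound 1 to compound 3 (0.02 log units; within the scatter). Compound 4 `COc1cc2cc(C(=O)NCc3ccccc3)c(=O)oc2cc1OCCCOc1no[n+]([O-])c1S(=O)(=O)c1ccccc1` differs from compound 2 by phenyl in place of phenethyl on a saturated chain carbon bound to an amide-type nitrogen. The step from compound 1 to compound 2 altered the same chain position and moved nothing beyond the scatter, and the other two steps, which exchanged the whole group on the amide nitrogen, were equally flat. Compound 4 is therefore expected to show no step beyond the scatter, no change at the digits printed from compound 2 to compound 4 (within the scatter). Compound 4 is estimated at 760 nM, with a range from 400 nM to 1500 nM.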

Compound 4, half-maximal inhibitory concentration: 1060 nM
Compound 4: middle estimate off by 1.4-fold (0.14 log units), on the low side, and the stated range covers the measured number.
By their numbers in this assay, from the lowest: compounds 3, 2, 1 and 4 (each within the scatter of the next).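

Shortening the chain on the amide nitrogen from 3-phenylpropyl to benzyl gives a 1.4-fold higher number from compound 2 to compound 4 (0.14 log units; within the scatter) in this assay and so stays inside the usual scatter. Removing the fluoro gives a 1.4-fold higher number from compound 1 to compound 4 (0.14 log units; within the scatter) and benzyl against 4-methoxyphenyl gives a 1.5-fold higher number from compound 3 to compound 4 (0.16 log units; within the scatter), so all four compounds remain within the scatter of one another despite these changes to the amide side chain. Nothing available explains this flatness.

The compounds shown leave open whether a basic amine or a carboxylic acid at the end of this chain would give a step beyond the scatter. They also leave open whether a chain longer than 3-phenylpropyl would do so.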